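From dichlorophenyl to dimethoxyphenyl on a shared core

This account rests on a few compounds, and the source may have more. Where it says the series, first, only, none or still open, it means among the compounds named here.

Compound 1, `Nc1cc(N)c2nc(-c3ccccc3)c(NCc3ccc(Cl)c(Cl)c3)nc2c1`: 9770 nM
Compound 2, `Nc1cc(N)c2nc(-c3ccccc3)c(Sc3ccc(F)cc3)nc2c1`: 50100 nM
Compound 3, `Nc1cc(N)c2nc(-c3ccccc3)c(Oc3ccc(F)cc3)nc2c1`: 50100 nM

These three compounds share one core and were compared in a functional assay on SW-620 cells (Homo sapiens) for inhibition, read by sulforhodamine B assay, with a stated time of 48 h; on this read-out higher numbers stand for weaker inhibition of growth and lower numbers for stronger inhibition of growth. Compound 1 gives the lowest of the three numbers; compound 2 and compound 3 both sit higher, and the gap from compound 1 to either of them is beyond the scatter. Within the data shown here, the only step between measured compounds that differ in one place is no change at the digits printed from compound 2 to compound 3 (within the scatter), which exchanges (4-fluorophenyl)sulfanyl for 4-fluorophenoxy and leaves the number where it was. Compound 4, `COc1ccc(CNc2nc3cc(N)cc(N)c3nc2-c2ccccc2)cc1OC`, differs from compound 1 in 3,4-dimethoxyphenyl in place of 3,4-dichlorophenyl on a saturated chain carbon bound to a nitrogen on an aromatic ring. Among the measured compounds shown here, no measured step touches the group on the saturated chain carbon bound to a nitrogen on the aromatic ring, so the single known step gives no guidance for this change, and the expectation rests on compound 1 alone. The step expected is a 1.5-fold higher number from compound 1 to compound 4 (0.19 log units; within the scatter), which is no change beyond the scatter. Compound 4 is estimated at 15000 nM, within 4000 nM to 50000 nM.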

Compound 4, concentration for total growth inhibition: < 100000 nM
Compound 4: a limit, no number; the forecaster's own chance of this, stated with the estimate: 10%; the middle value does not contradict the limit.
By their numbers in this assay, from the lowest: compound 1; then compounds 2 and 3 (each within the scatter of the next).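

In this assay compound 4 gives < 100000 nM, which is a limit and not a number. No new step can be read from it, so compound 1 and compound 4 stay unconnected. The compounds shown leave open whether 3,4-dimethoxyphenyl in place of 3,4-dichlorophenyl changes the number at all.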